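The compounds below may be only part of what the source reports. "The series", "measured", "known", "first", "only" and "open" are said of these compounds alone.

Working notes on the amide series built on the core of compound 1 `CCn1c(C(=O)N[C@@H](CC(=O)OC)C(=O)OC)ccc1C(CC)(CC)c1ccc(OCS(=O)(=O)c2ccccc2)c(C)c1`. In a functional assay on BXPC-3 cells (Homo sapiens) for antiproliferative activity, read by MTT assay, with a stated time of 24 h (on this read-out lower numbers stand for stronger inhibition and higher numbers for weaker inhibition), compound 1 gives > 50000 nM, which is a limit of the assay and not a number (the limit of > 50000 nM in this assay, at which 1 of the 3 values shown sits). Compound 2 `CCN(CC)CCNC(=O)c1ccc(C(CC)(CC)c2ccc(OCS(=O)(=O)c3ccccc3)c(C)c2)n1CC` gives 6270 nM in this assay. Compound 3 `CCn1c(C(=O)N[C@H](CO)C(C)C)ccc1C(CC)(CC)c1ccc(OCS(=O)(=O)c2ccccc2)c(C)c1` gives 7720 nM in this assay; this is the higher of the two numbers shown, but the step of a 1.2-fold higher number from compound 2 to compound 3 (0.09 log units; within the scatter) is within the scatter, so no order between compounds 2 and 3 is claimed. The steps of an at least 7.9-fold lower number from compound 1 to compound 2 (0.90 log units; beyond the scatter) and an at least 6.4-fold lower number from compound 1 to compound 3 (0.81 log units; beyond the scatter) are both beyond the scatter.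

Compound 4 `CCn1c(C(=O)N[C@@H](CCC(=O)O)C(=O)O)ccc1C(CC)(CC)c1ccc(OCS(=O)(=O)c2ccccc2)c(C)c1` is not yet measured. It differs from compound 3 by 1,3-dicarboxypropyl in place of 1-(hydroxymethyl)-2-methylpropyl on an amide-type nitrogen. Among the compounds with values here, the step that bears on this is the one from compound 1, where the 1,2-bis(methoxycarbonyl)ethyl group sits on the same nitrogen: an at least 6.4-fold lower number from compound 1 to compound 3 (0.81 log units; beyond the scatter). Compound 4 moves back toward that kind of substituent, with carboxy groups in place of methoxycarbonyl groups, so a rise of similar size, possibly to the limit, is expected. For compound 4 in this assay the estimate is 35000 nM, with a range from 8000 nM to 100000 nM. This estimate is expected to mean a step of a 4.5-fold higher number from compound 3 to compound 4 (0.66 log units; beyond the scatter).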

Compound 4, half-maximal inhibitory concentration: > 50000 nM
Compound 4: a limit, no number; the forecaster's own chance of this, stated with the estimate: 55%; middle value at least 1.4-fold (0.15 log units) from the limit.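

With 1,3-dicarboxypropyl on the amide-type nitrogen, this assay shows an at least 6.4-fold higher number from compound 3 to compound 4 (0.81 log units; beyond the scatter) and an at least 7.9-fold higher number from compound 2 to compound 4 (0.90 log units; beyond the scatter), so the loss holds against both measured compounds. Before this result, only the 1,2-bis(methoxycarbonyl)ethyl group stood at the top of the range, and now a group with free carboxy groups stands there too, so this outcome at the position is not confined to that one group. The result for compound 4 is a limit of the assay and not a number, and compound 1 shares that limit: the limit of > 50000 nM in this assay, at which 2 of the 4 values shown sit.

The two limits leave the step between compound 1 and compound 4 unreadable, so carboxy and methoxycarbonyl groups cannot be ranked here. Also open, on these data alone, is whether a single carboxylic acid on a shorter chain, or a primary amine, would read like compound 2 and compound 3 or sit at the limit.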